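This account rests on a few compounds, and the source may have more. Where it says the series, first, only, none or still open, it means among the compounds named here.

Compound 1 `O=c1c(Cl)c(CSC(=S)N2CCCCC2)oc2ccccc12` and compound 2 `CC(C)N(C(=S)SCc1oc2ccccc2c(=O)c1Cl)C(C)C` share one core and differ only at the thiocarbonyl carbon. In a functional assay on MDA-MB-435S cells (Homo sapiens) for antiproliferative activity, read by MTT assay, with a stated time of 72 h (on this read-out lower numbers stand for stronger inhibition and higher numbers for weaker inhibition), compound 1 gives 770 nM, while compound 2 gives 23600 nM. The change between them, (piperidin-1-yl in place of diisopropylamino on a thiocarbonyl carbon), produced a 31-fold lower number from compound 2 to compound 1 (1.49 log units; beyond the scatter). Compound 3 `COc1ccc2oc(CSC(=S)N(C(C)C)C(C)C)cc(=O)c2c1` carries a different core; how that core differs from the core of compound 2 is not broken down here. In this assay compound 3 gives 22100 nM, a value within the usual scatter of that of compound 2. Compound 4 `COc1ccc2oc(CSC(=S)N3CCCCC3)cc(=O)c2c1` keeps the core of compound 3 and carries the same change, (piperidin-1-yl in place of diisopropylamino on a thiocarbonyl carbon), at the same place. For compound 4 the expected step is a 28-fold lower number from compound 3 to compound 4 (1.44 log units; beyond the scatter), because the same change gave a 31-fold lower number from compound 2 to compound 1 (1.49 log units; beyond the scatter) on the other core. Compound 4 is therefore estimated at 800 nM, with a likely range from 250 nM to 2500 nM.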

Compound 4, half-maximal inhibitory concentration: 1500 nM
Compound 4: the middle estimate sits 1.9-fold (0.27 log units) below what was measured, and the stated range covers the measured number.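

Putting piperidin-1-yl in place of diisopropylamino on the thiocarbonyl carbon again lowers the number in this assay, with a 15-fold lower number from compound 3 to compound 4 (1.17 log units; beyond the scatter). On these two cores the change therefore points the same way, and its size also carries over: the same change on two cores in this assay, a 31-fold lower number (1.49 log units; beyond the scatter) from compound 2 to compound 1 and a 15-fold lower number (1.17 log units; beyond the scatter) from compound 3 to compound 4, 2.1-fold (0.32 log units) apart, within the scatter of two such steps. Going by these compounds alone, this rests on only two pairs in one cell line, so it does not show that the change would carry to other cores, and it does not explain why the two amino groups differ.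

The compounds shown leave open whether another amine on the thiocarbonyl carbon, such as morpholine or pyrrolidine, would behave like piperidin-1-yl or like diisopropylamino. They also leave open how a dimethylamino group would compare.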